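The compounds below may be only part of what the source reports. "The series", "measured", "known", "first", "only" and "open" are said of these compounds alone.

Measured so far:
compound 1 `CCOc1ccc(F)cc1C(C)NC(=O)NS(=O)(=O)c1ccc(C)cc1`, > 300000 nM
compound 2 `CCOc1ccc(F)cc1C(C)NC(=O)NS(=O)(=O)c1ccccc1`, > 300000 nM
compound 3 `COc1ccc(OC)c(CNC(=O)N(C)S(=O)(=O)c2ccccc2)c1`, 21300 nM

In a functional assay on thoracic aorta (Rattus norvegicus, strain Wistar), with a stated time of 15 min (on this read-out lower numbers stand for an effect already at smaller amounts and higher numbers for an effect only at larger amounts of compound), compound 1 reaches only a limit, > 300000 nM. Compound 2 in this assay also stays at a limit, > 300000 nM. Compound 3 alone gives a number in this assay, 21300 nM. The other two sit at the limit of > 300000 nM in this assay, at which 2 of the 3 values shown sit. From compound 2 to compound 1 the change is methyl in place of hydrogen on an aromatic carbon, and the step that the two limits leave unreadable from compound 2 to compound 1 cannot be sized. How the core of compound 3 differs from that of compound 2 is not broken down here.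

Compound 4 `COc1ccc(OC)c(CNC(=O)N(C)S(=O)(=O)c2ccc(C)cc2)c1` carries the same change against compound 3, (methyl in place of hydrogen on an aromatic carbon). The expected step is a 1.2-fold lower number from compound 3 to compound 4 (0.07 log units; within the scatter), kept small since the change enters a single carbon and the like step from compound 2 to compound 1 gives no readable size. Compound 4 is estimated at 18000 nM in this assay, between 6000 nM and 60000 nM.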

Compound 4, half-maximal effective concentration: 20900 nM
Compound 4: the middle estimate sits 1.2-fold (0.06 log units) below what was measured; the measured number falls inside the stated range.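

In this assay, methyl in place of hydrogen on the aromatic carbon gives a 1.0-fold lower number from compound 3 to compound 4 (0.01 log units; within the scatter), so on the core of compound 3 the change from phenyl to 4-methylphenyl leaves the two values within the scatter of each other. The like step from compound 2 to compound 1 cannot be read, as both compounds stand at a limit and not at a number: the limit of > 300000 nM in this assay, at which 2 of the 4 values shown sit. The series therefore offers one readable step, which shows nothing about whether the change carries from one core to the other.

Open, as far as these compounds go, is whether an amine, a carboxylic acid or a longer chain in place of the methyl would shift the read-out on the core of compound 3. Equally open, from the compounds shown here alone, is whether any such group gives a readable number on the core of compound 2.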